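Chain growth on a weak lactam-like core

The source may hold more compounds than are shown below. What is called first, only, known or untested is meant among the compounds shown, and "the series" means these compounds.

Compound 1 `C=C1CN(C)N(c2ccccc2)C1=O` gives 56000 nM in a functional assay on NALM-6 cells (Homo sapiens) for inhibition, read by MTT assay, with a stated time of 48 h; on this read-out lower numbers stand for stronger inhibition and higher numbers for weaker inhibition. Within the data shown here, compound 2 `C=C1C(=O)N(c2ccccc2)N(C)C1CC` gives 576000 nM in this assay, the higher of the two numbers, and the only step so far, a 10-fold higher number from compound 1 to compound 2 (1.01 log units; beyond the scatter), was large. Compound 3 `C=C1C(=O)N(c2ccccc2)N(C)C1CCCCCCCCC` differs from compound 2 by heptyl in place of hydrogen on a saturated chain carbon, two bonds along the chain from a saturated ring carbon. Among the measured compounds shown here, that step bears on the same chain, so a further move toward weaker inhibition is expected for compound 3, though with no second example the size is uncertain. Compound 3 is estimated at 900000 nM, in the range 200000 nM to 4000000 nM, expected as a 1.6-fold higher number from compound 2 to compound 3 (0.19 log units; within the scatter).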

Compound 3, half-maximal inhibitory concentration: 57500 nM
Compound 3: middle estimate off by 16-fold (1.19 log units), on the high side, and the stated range ends above it.
By their numbers in this assay, from the lowest: compounds 1 and 3 (each within the scatter of the next); then compound 2.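

In this assay, the step is a 10-fold lower number from compound 2 to compound 3 (1.00 log units; beyond the scatter), the opposite direction to the step that added ethyl. Growth of this chain therefore does not push the number one way: heptyl on the ethyl chain brings compound 3 back within the scatter of compound 1, which has no chain at this ring carbon. Still open, from the compounds shown here alone, is whether chains of intermediate length, such as propyl or butyl, fall between these values, and whether a chain ending in an amine or a carboxylic acid behaves alike. No measured evidence here accounts for this reversal.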